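Cyclopentylamino for Pentyloxy: Expected Cytotoxicity of Compound 4

The source may hold more compounds than are shown below. What is called first, only, known or untested is meant among the compounds shown, and "the series" means these compounds.

Compound 1 `CCCCSc1nc(N)nc2c1ncn2/C=C1/CC1(CO)CO` gives in an ADME assay on HFF cells (Homo sapiens) for cytotoxicity, with a stated time of 8 days (on this read-out higher numbers stand for lower toxicity in this test and lower numbers for higher toxicity in this test), only a limit of the assay, not a number: > 300000 nM.
Compound 2 `CCCNc1nc(N)nc2c1ncn2/C=C1/CC1(CO)CO` likewise gives only a limit: > 300000 nM.
Compound 3 `CCCCCOc1nc(N)nc2c1ncn2/C=C1/CC1(CO)CO` gives 259000 nM.

For the measured compounds named here, compound 3 is therefore the only compound with an actual number; the other two sit at the limit of > 300000 nM in this assay, at which 2 of the 3 values shown sit. Compound 4 `Nc1nc(NC2CCCC2)c2ncn(/C=C3/CC3(CO)CO)c2n1` differs from compound 3 by cyclopentylamino in place of pentyloxy on an aromatic carbon. Going by the values given here, the steps that bear on this change are an at least 1.1-fold lower number from compound 1 to compound 3 (0.06 log units; that floor lies within the scatter) and an at least 1.1-fold lower number from compound 2 to compound 3 (0.06 log units; that floor lies within the scatter), both floors that lie within the scatter, and a step that the two limits leave unreadable from compound 1 to compound 2, whose size the two limits hide. Since compound 2, which also carries an alkylamino group, reached the limit, compound 4 is expected to return to that region with 300000 nM (range 150000 nM to 600000 nM), which would mean a 1.2-fold higher number from compound 3 to compound 4 (0.06 log units; within the scatter).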

Compound 4, half-maximal cytotoxic concentration: > 300000 nM
Compound 4: only a limit was reported; the forecaster's own chance of this, stated with the estimate: 55%; the middle value lies on the limit itself.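

In this assay, cyclopentylamino in place of pentyloxy gives an at least 1.1-fold higher number from compound 3 to compound 4 (0.06 log units; that floor lies within the scatter), so this position also accepts a ring-bearing amino group, not only the open-chain propylamino of compound 2, with no measured gain in toxicity. The steps between compound 4 and compounds 1 and 2 cannot be read, since each joins two limits. The limit now gathers most of the set: the limit of > 300000 nM in this assay, at which 3 of the 4 values shown sit.

Going by these compounds, how far apart the compounds at that limit truly lie stays open. Also open, on these data alone, is whether a phenylamino group or a longer chain on the nitrogen at this carbon would give an actual number.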